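A 4-Methoxybenzyl in Place of a 3,4-Dichlorobenzyl

The source may report more compounds than this note shows. Statements on the series, on what has been measured and on what is new or still open speak of the compounds shown alone.

Compound 1 `Nc1cc(N)c2nc(-c3ccccc3)c(NCc3ccc(Cl)c(Cl)c3)nc2c1` was examined in a functional assay on SW-620 cells (Homo sapiens) for inhibition, read by sulforhodamine B assay, with a stated time of 48 h; on this read-out higher numbers stand for lower toxicity in this test and lower numbers for higher toxicity in this test. For compound 1 only a limit is recorded there, < 100000 nM. Compound 2 `CCOC(=O)[C@H](CCC(=O)O)NC(=O)c1ccc(Oc2nc3cc(N)cc(N)c3nc2-c2ccccc2)cc1` likewise reaches only a limit in this assay, < 100000 nM. Compound 3 `CCOC(=O)[C@H](CCC(=O)O)NC(=O)c1ccc(CNc2nc3cc(N)cc(N)c3nc2-c2ccccc2)cc1` also gives only a limit in this assay, < 100000 nM. Compound 1 therefore stands where every measured value sits, as the limit of < 100000 nM in this assay, at which 3 of the 3 values shown sit, shows. Compound 4 `COc1ccc(CNc2nc3cc(N)cc(N)c3nc2-c2ccccc2)cc1` has not yet been measured; it differs from compound 1 by 4-methoxyphenyl in place of 3,4-dichlorophenyl on a saturated chain carbon bound to a nitrogen on an aromatic ring. Within the data shown here, no step between measured compounds is available, and with every value a limit no change beyond the scatter can be anticipated in this assay. For compound 4 the expected step is a step that the limit leaves unreadable from compound 1 to compound 4, so its estimated value is 30000 nM, within a range from 5000 nM to 100000 nM.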

Compound 4, concentration lethal to 50% of the cells: 70800 nM
Compound 4: middle estimate off by 2.4-fold (0.37 log units), on the low side, within the range that was stated.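

Compound 1 carries only a limit, so no step from it to compound 4 can be read in this assay: the limit of < 100000 nM in this assay, at which 3 of the 4 values shown sit.

The compounds shown leave open whether 4-methoxyphenyl in place of 3,4-dichlorophenyl changes the result in this assay at all.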